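This account rests on a few compounds, and the source may have more. Where it says the series, first, only, none or still open, it means among the compounds named here.

Measured so far:
compound 1, `CCCCCCCC/C=C/CCCCCCCC(=O)Nc1cc(C(=O)OC)ccc1OC`: 430 nM
compound 2, `CCCCCCCC/C=C/CCCCCCC(C)(C)C(=O)Nc1c(OC)cc(OC)cc1OC`: 44 nM
compound 3, `CCCCCCCCCCCCCCC(=O)Nc1c(OC)cc(OC)cc1OC`: 65 nM

All three numbers come from an assay on microsomes from intestine for inhibition of acyl-CoA:cholesterol acyltransferase (Oryctolagus cuniculus); a higher number here means a weaker inhibitor, a lower number a stronger inhibitor. Compound 3 gives the second highest of the three numbers. Its nearest neighbour is compound 2, whose number is lower but within the scatter, so no order between compound 2 and compound 3 can be read from these two values. Compound 1 lies furthest from compound 3, with a clearly higher number, beyond the scatter. No two of the measured compounds differ in one place only, so none of the pairs is taken as a single step.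

Compound 4, `CCCCCCCCCCCCCCCCCC(=O)Nc1c(OC)cc(OC)cc1OC`, has not yet been measured. It differs from compound 3 by propyl in place of hydrogen on a saturated chain carbon, ten or more bonds along the chain from a carbonyl carbon. The change lengthens the saturated chain far from the carbonyl and adds no ring, donor or acceptor. The expectation in this assay is a step of modest size at most, if anything toward a lower number, but nothing beyond the scatter: the step from compound 3 to compound 4 is estimated as a 1.3-fold lower number from compound 3 to compound 4 (0.11 log units; within the scatter). For compound 4 the expected value is 50 nM, with the range 20 nM to 150 nM.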

Compound 4, half-maximal inhibitory concentration: 52 nM
For compound 4 the middle estimate is 1.0-fold (0.02 log units) below the measured one; measured number inside the range.
By their numbers in this assay, from the lowest: compounds 2, 4 and 3 (each within the scatter of the next); then compound 1.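

In this assay, for the compounds shown here, propyl in place of hydrogen on a saturated chain carbon, ten or more bonds along the chain from a carbonyl carbon, gives a 1.3-fold lower number from compound 3 to compound 4 (0.10 log units; within the scatter) and provides the first single-place pair. At this position, the added propyl leaves no readable change in the number, and no order between the two compounds can be drawn. Nothing measured here bears on why the step is this small.

As far as these compounds go, what a longer chain, or a carboxylic acid or an amine at this same chain carbon, would do to the number remains open. From the compounds shown here alone, the separate contributions of the chain and core in compound 1 and compound 2 also remain open, with neither compound joined to another by a single step.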